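The source may report more compounds than this note shows. Statements on the series, on what has been measured and on what is new or still open speak of the compounds shown alone.

Compound 1 `Nc1scc(CN2CCN(c3ccc(Cl)c(C(F)(F)F)c3)CC2)c1C(=O)c1ccc(Cl)cc1`: -2.5%
Compound 2 `Nc1scc(CN2CCN(C3CCCCCC3)CC2)c1C(=O)c1ccc(Cl)cc1`: 2.9%
Compound 3 `Nc1scc(CN2CCN(c3cccc4ccccc34)CC2)c1C(=O)c1ccc(Cl)cc1`: 8.7%

Going by the values given here, in a functional assay on CHO cells with adenosine receptor A1 (Homo sapiens) as the target, read by cAMP accumulation and immunoassay, with a stated time of 6 min, tested at 0.01 uM (on this read-out higher numbers stand for a weaker effect at the one concentration tested and lower numbers for a stronger effect), compound 3 has the highest of the three numbers, but its gap to compound 2 lies within the scatter; only the step of a number 11.2 percentage points higher from compound 1 to compound 3 (beyond the scatter) is beyond it. Compound 4 `Nc1scc(CN2CCN(c3ccc(F)c(F)c3)CC2)c1C(=O)c1ccc(Cl)cc1` differs from compound 3 in one place: 3,4-difluorophenyl in place of naphthalen-1-yl on an amine nitrogen in a ring. Among the compounds with values here, the steps that bear on this are the earlier swaps of the group on the same ring nitrogen, a number 11.2 percentage points higher from compound 1 to compound 3 (beyond the scatter) and a number 5.8 percentage points higher from compound 2 to compound 3 (within the scatter), both small. Compound 1 carries 4-chloro-3-(trifluoromethyl)phenyl on that nitrogen and gives -2.5%. A modest downward step is therefore expected, a number 6.7 percentage points lower from compound 3 to compound 4 (within the scatter). Compound 4 is expected to give about 2%, within -9% to 13%.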

Compound 4, a percentage reported as activity, at one concentration (the size of the read-out at that concentration, not a potency): -3.2%
For compound 4 the middle estimate is 5.2 percentage points above the measured one, within the range that was stated.
By their numbers in this assay, from the lowest: compounds 4, 1, 2 and 3 (each within the scatter of the next, the first and the last beyond it).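

In this assay, the 3,4-difluorophenyl group gives a number 11.9 percentage points lower from compound 3 to compound 4 (beyond the scatter), so the naphthalen-1-yl group now stands apart from two substituted phenyl groups rather than one. The two phenyl groups cannot be told apart, with a number 0.7 percentage points lower from compound 1 to compound 4 (within the scatter), and the same holds for the cycloheptyl group, with a number 6.1 percentage points lower from compound 2 to compound 4 (within the scatter). No measurement here accounts for these steps. The compounds shown leave open how an unsubstituted phenyl ring or an open-chain butyl group would read on this ring nitrogen. They also leave open whether this single-concentration order would hold as an order of potency.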